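The compounds below may be only part of what the source reports. "The series", "measured", "known", "first", "only" and "open" are said of these compounds alone.

Measured so far in an ADME assay on NIH3T3 cells (Mus musculus) for cytotoxicity, read by MTT assay, with a stated time of 24 h; on this read-out higher numbers stand for weaker inhibition and lower numbers for stronger inhibition:
- compound 1 `O=C(CSc1nnc(-c2ccncc2)o1)N/N=C/c1ccc([N+](=O)[O-])cc1`: 195000 nM
- compound 2 `O=C(CSc1nnc(-c2ccncc2)o1)N/N=C/c1cccc(F)c1`: 205000 nM
- compound 3 `O=C(CSc1nnc(-c2ccncc2)o1)N/N=C/c1cccc(C(F)(F)F)c1`: 169000 nM

Compound 1 at 195000 nM lies within the scatter of both other compounds, so the three numbers form one level. Compound 4 `O=C(CSc1nnc(-c2ccncc2)o1)N/N=C/c1ccccc1F` is still unmeasured. It has 2-fluorophenyl in place of 4-nitrophenyl on a carbon with a double bond to nitrogen. The closest evidence is a 1.1-fold higher number from compound 1 to compound 2 (0.02 log units; within the scatter), which has 3-fluorophenyl entering at the same place. The change of trifluoromethyl in place of fluoro, a 1.2-fold lower number from compound 2 to compound 3 (0.08 log units; within the scatter), also stays small. No step beyond the scatter is therefore expected in this assay. The estimated change is a 1.0-fold lower number from compound 1 to compound 4 (0.01 log units; within the scatter). For compound 4 the expected value is 190000 nM, with an estimated range of 130000 nM to 270000 nM.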

Compound 4, half-maximal inhibitory concentration: 142000 nM
Compound 4: the middle estimate sits 1.3-fold (0.13 log units) above what was measured; the measured number falls inside the stated range.
By their numbers in this assay, from the lowest: compounds 4, 3, 1 and 2 (each within the scatter of the next).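

In this assay 2-fluorophenyl in place of 4-nitrophenyl gives a 1.4-fold lower number from compound 1 to compound 4 (0.14 log units; within the scatter) and 2-fluorophenyl in place of 3-fluorophenyl gives a 1.4-fold lower number from compound 2 to compound 4 (0.16 log units; within the scatter) on a carbon with a double bond to nitrogen. The new point is that changing where fluoro sits on the phenyl ring, as between compound 2 and compound 4, produces no step beyond the scatter. No measurement available here explains this flat picture. Still open, as far as these compounds go, is whether an amine or a carboxylic acid on this phenyl ring would leave the shared level. A longer chain in place of the ring is equally untested in these compounds.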